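Series notes: aryl ring variation on the chain

This account rests on a few compounds, and the source may have more. Where it says the series, first, only, none or still open, it means among the compounds named here.

Of the compounds shown here, three with the shared core have been measured in a functional assay on SW-620 cells (Homo sapiens) for cytotoxicity, read by MTT assay, with stated times of 4 h and 72 h, tested at 2 uM; on this read-out lower numbers stand for stronger inhibition and higher numbers for weaker inhibition. Compound 1 `COc1ccc(/C=C/C(=O)c2ccc(Nc3cc(C)nc4nc(SCc5nc6ccccc6[nH]5)nn34)cc2)cc1` gives 170 nM and stands second highest of the three numbers. Compound 3 `Cc1cc(Nc2ccc(C(=O)/C=C/c3ccccc3)cc2)n2nc(SCc3nc4ccccc4[nH]3)nc2n1` gives 130 nM, and compound 2 `Cc1ccc(/C=C/C(=O)c2ccc(Nc3cc(C)nc4nc(SCc5nc6ccccc6[nH]5)nn34)cc2)cc1` gives 1520 nM. The step of a 1.3-fold lower number from compound 1 to compound 3 (0.12 log units; within the scatter) is within the scatter, while an 8.9-fold higher number from compound 1 to compound 2 (0.95 log units; beyond the scatter) and a 12-fold lower number from compound 2 to compound 3 (1.07 log units; beyond the scatter) are beyond it.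

Compound 4 `Cc1cc(Nc2ccc(C(=O)/C=C/c3cccc(F)c3)cc2)n2nc(SCc3nc4ccccc4[nH]3)nc2n1` is not yet measured. It differs from compound 1 by 3-fluorophenyl in place of 4-methoxyphenyl on a double-bonded chain carbon bound to a double-bonded chain carbon. The measured steps that bear on this change both alter the group on the double-bonded chain carbon: methyl in place of methoxy, an 8.9-fold higher number from compound 1 to compound 2 (0.95 log units; beyond the scatter), and hydrogen in place of methoxy, a 1.3-fold lower number from compound 1 to compound 3 (0.12 log units; within the scatter). Going by the values given here, no measured compound carries fluorine on that ring, so the direction of a 3-fluorophenyl change is not anchored; the closest guide is compound 3, whose step from compound 1 is within the scatter. The expected step is therefore small, a 1.3-fold higher number from compound 1 to compound 4 (0.11 log units; within the scatter), with a wide range to cover the possibility seen with compound 2. For compound 4 the estimated value in this assay is 220 nM, between 70 nM and 800 nM.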

Compound 4, half-maximal inhibitory concentration: 590 nM
Compound 4: the middle estimate sits 2.7-fold (0.43 log units) below what was measured; measured number inside the range.
By their numbers in this assay, from the lowest: compounds 3 and 1 (each within the scatter of the next); then compound 4; then compound 2.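

In this assay fluoro in place of hydrogen on the aromatic ring costs activity (a 4.5-fold higher number from compound 3 to compound 4 (0.66 log units; beyond the scatter)), so this ring does not tolerate every substituent, and compound 4 joins compound 2 on the weaker side of the unsubstituted compound 3. The change from 4-methoxyphenyl to 3-fluorophenyl is also beyond the scatter (a 3.5-fold higher number from compound 1 to compound 4 (0.54 log units; beyond the scatter)), whereas the change from 4-methylphenyl to 3-fluorophenyl goes the other way (a 2.6-fold lower number from compound 2 to compound 4 (0.41 log units; beyond the scatter)), which places compound 4 at an intermediate level and shows that the substituted rings do not behave alike. No measurement at hand gives a cause for these steps.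

The two steps from compounds 1 and 2 change both the substituent and its ring position, so the effect of each stays unresolved. As far as these compounds go, how 4-fluorophenyl, 3-methoxyphenyl or an amine on this ring would read remains open.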